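Trimming the Carbinol Methyl in a Steroid-Enzyme Inhibitor Series

The compounds below may be only part of what the source reports. "The series", "measured", "known", "first", "only" and "open" are said of these compounds alone.

Of the compounds shown here, two on a shared core have been measured so far. In an assay on isolated protein for inhibition of steroid 17-alpha-hydroxylase/17,20 lyase (Homo sapiens) (on this read-out lower numbers stand for stronger inhibition and higher numbers for weaker inhibition), compound 1 `CC(=O)Nc1cccc(-c2ccc([C@@](O)(c3c[nH]cn3)C(C)C)cc2)c1` gives 340 nM. Compound 2 `CC(=O)Nc1cccc(-c2ccc(C(C)(O)c3c[nH]cn3)cc2)c1` gives 38 nM in this assay. Among the compounds with values here, compound 2 therefore stands with the lowest of the two numbers; its only neighbour is compound 1, whose higher number lies beyond the scatter of repeated measurement.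

Compound 3 `CC(=O)Nc1cccc(-c2ccc(C(O)c3c[nH]cn3)cc2)c1` has not yet been measured. It differs from compound 2 by a single change: hydrogen in place of methyl on a saturated chain carbon bound to two aromatic carbons and an oxygen on a saturated carbon. Within the data shown here, no step between measured compounds that differ in one place has been recorded, so the size of this kind of step in this assay is not known from the data at hand. A modest loss, or no change beyond the scatter, is expected. In this assay compound 3 is expected to give about 70 nM, within a range from 18 nM to 280 nM, a step of a 1.8-fold higher number from compound 2 to compound 3 (0.27 log units; within the scatter).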

Compound 3, half-maximal inhibitory concentration: 77 nM
Compound 3: the middle estimate sits 1.1-fold (0.04 log units) below what was measured, within the range that was stated.
By their numbers in this assay, from the lowest: compound 2; then compound 3; then compound 1.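

In this assay, within the data shown here, hydrogen in place of methyl on this carbon gives a 2.0-fold higher number from compound 2 to compound 3 (0.31 log units; beyond the scatter), the first measured step at this position. The step is modest and lies only just beyond the usual scatter, so on this read-out the methyl can be lost at a small cost, and the change from 1-(1H-imidazol-4-yl)-1-hydroxyethyl to (1H-imidazol-4-yl)(hydroxy)methyl does not abolish inhibition. Nothing available here accounts for the size or direction of this shift.

The compounds shown leave open how an ethyl or a cyclopropyl group would read on the same carbon, which would help fill in the picture beyond methyl and hydrogen. They also leave open what would happen if an amine or a methoxy group took the place of the hydroxyl on that carbon.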